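The source may report more compounds than this note shows. Statements on the series, on what has been measured and on what is new or still open speak of the compounds shown alone.

The study compares two pairs of compounds that share the same change and differ in their cores. Compound 1, `CCCCCCCc1[nH]c2ccccc2c(=O)c1C(=O)OCC`, carries an ester; compound 2, `CCCCCCCc1[nH]c2ccccc2c(=O)c1C(=O)O`, is its acid. In a physicochemical assay for solubility, read by HPLC, at pH 7.4 (on this read-out higher numbers stand for higher solubility and lower numbers for lower solubility), compound 1 gives 5000 nM, and compound 2 gives 15000 nM. The change between them is hydrogen in place of ethyl on an oxygen next to a carbonyl group, and the step it made was a 3.0-fold higher number from compound 1 to compound 2 (0.48 log units; beyond the scatter).

Compound 3, `CCCCCCCc1[nH]c2ccncc2c(=O)c1C(=O)OCC`, is built on a different core; the difference between the two cores is not broken down here. In this assay compound 3 gives 50000 nM, the highest of the three numbers, with compound 2 its nearest neighbour and compound 1 furthest away. Compound 4, `CCCCCCCc1[nH]c2ccncc2c(=O)c1C(=O)O`, has not yet been measured. It differs from compound 3 by hydrogen in place of ethyl on an oxygen next to a carbonyl group, the same change as that from compound 1 to compound 2, applied on the same kind of place.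

For compound 4 in this assay the expected step is a 3.0-fold higher number from compound 3 to compound 4 (0.48 log units; beyond the scatter), resting on the step seen from compound 1 to compound 2, which was a 3.0-fold higher number from compound 1 to compound 2 (0.48 log units; beyond the scatter), beyond the usual scatter. Starting from compound 3 at 50000 nM, compound 4 is estimated to give 150000 nM. Among the measured compounds shown here, the expected range for compound 4 is estimated to run from 60000 nM to 400000 nM, since only one earlier step of this kind is available to set the size.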

Compound 4, solubility: 50000 nM
Compound 4: the middle estimate sits 3.0-fold (0.48 log units) above what was measured; the measured number lies below the stated range.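

In this assay, the change from ethoxycarbonyl to carboxy gave no change at the digits printed from compound 3 to compound 4 (within the scatter), whereas the same change on the core of compound 1 gave a 3.0-fold higher number from compound 1 to compound 2 (0.48 log units; beyond the scatter), so a step printed as beyond the scatter on one core was not repeated on the other. This shows that, in these two pairs, the step seen on one core did not predict the step on the other, and that the outcome of this change depended on which core carried it. Among the compounds shown here, it does not show how the change would behave on any further core, as each core contributes only a single pair, and nothing available here accounts for the difference between the two outcomes.

The compounds shown leave open whether a primary amide or a nitrile in place of the ethoxycarbonyl would follow the pattern of compound 2 or that of compound 4 on these two cores. They also leave open whether the two cores would still part ways with a shorter alkyl chain in place of the long chain shared by all four compounds, or with an amine added to the core.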